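From ethoxycarbonyl to carbamoyl on the shared core

The compounds below may be only part of what the source reports. "The series", "measured", "known", "first", "only" and "open" are said of these compounds alone.

In a functional assay (uterus) for inhibition, with Rattus norvegicus as the target (a higher number here means that more compound is needed for the effect, a lower number that less compound is needed), compound 2 (`CCOC(=O)c1cn2c(Br)cncc2n1`) stands in the middle of three measured compounds at 1.02 nM. Compound 1 (`Brc1cncc2nccn12`) gives 0.29 nM, and compound 3 (`OCc1cn2ccncc2n1`) gives 2.7 nM. Compound 4 (`NC(=O)c1cn2c(Br)cncc2n1`) differs from compound 2 by amino in place of ethoxy on a carbonyl carbon. Among the measured compounds shown here, only one measured step bears on this, and only indirectly: a 3.5-fold higher number from compound 1 to compound 2 (0.55 log units; beyond the scatter), a modest step that adds the ethoxycarbonyl in place of hydrogen. For the measured compounds named here, no measured step exchanges the ethoxy itself, so no step beyond the scatter is expected, and the direction remains open. The expected change is a 1.3-fold higher number from compound 2 to compound 4 (0.11 log units; within the scatter). Compound 4 is estimated at 1.3 nM, with an expected range from 0.35 nM to 5 nM.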

Compound 4, concentration for half-maximal effect: 0.41 nM
The estimate for compound 4 lay 3.2-fold (0.50 log units) above the measured number; low and high end bracket the measured number.
By their numbers in this assay, from the lowest: compounds 1 and 4 (each within the scatter of the next); then compound 2; then compound 3.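

In this assay, the group on the carbonyl carbon proves to matter: amino in place of ethoxy gives a real change (a 2.5-fold lower number from compound 2 to compound 4 (0.40 log units; beyond the scatter)). Carbamoyl in place of hydrogen on the aromatic carbon, unlike ethoxycarbonyl (1>2 step: a 3.5-fold higher number from compound 1 to compound 2 (0.55 log units; beyond the scatter)), stays within the scatter of the core of compound 1 (step: a 1.4-fold higher number from compound 1 to compound 4 (0.15 log units; within the scatter)). Nothing measured here explains this difference between the two groups. As far as these compounds go, it remains open how a carboxylic acid or a methylamino group on that carbonyl carbon would compare with amino and ethoxy.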